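A Methyl Group Added to Compound 3

The source may hold more compounds than are shown below. What is called first, only, known or untested is meant among the compounds shown, and "the series" means these compounds.

Three related compounds have been measured. In a functional assay on HeLa cells (Homo sapiens) for antiproliferative activity, read by MTT assay, with a stated time of 72 h (a lower number here means a stronger inhibitor, a higher number a weaker inhibitor), compound 1 (`Cc1ccccc1N1CCN(C2=CC(=O)c3cccc(O)c3C2=O)CC1`) gives 7200 nM, compound 2 (`O=C1C=C(N2CCN(c3ccccc3)CC2)C(=O)c2c(O)ccc(O)c21`) gives 2100 nM, and compound 3 (`O=C1C=C(N2CCC(c3ccccc3)CC2)C(=O)c2c(O)cccc21`) gives 8600 nM. Compound 3 thus stands within the scatter of compound 1, while its number lies above that of compound 2 by a margin beyond the scatter.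

Compound 4 (`Cc1ccccc1C1CCN(C2=CC(=O)c3cccc(O)c3C2=O)CC1`) departs from compound 3 in one place: methyl in place of hydrogen on an aromatic carbon. This is methyl in place of hydrogen on an aromatic carbon, turning phenyl into 2-methylphenyl. Among the measured compounds shown here, no measured pair isolates such a change, so no step beyond the scatter is expected in this assay. The nearest guide is compound 1, which also carries 2-methylphenyl and gives 7200 nM, within the scatter of compound 3. The expected change is small, an estimated 1.1-fold lower number from compound 3 to compound 4 (0.06 log units; within the scatter), and its direction remains uncertain. For compound 4 the estimated value is 7500 nM, with an expected range from 3200 nM to 17000 nM.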

Compound 4, half-maximal inhibitory concentration: 9700 nM
Compound 4: the middle estimate sits 1.3-fold (0.11 log units) below what was measured, and the stated range covers the measured number.
By their numbers in this assay, from the lowest: compound 2; then compounds 1, 3 and 4 (each within the scatter of the next).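

In this assay, among the compounds shown here, this pair is the first to isolate the change, and it gives a 1.1-fold higher number from compound 3 to compound 4 (0.05 log units; within the scatter), a step within the scatter. Methyl in place of hydrogen on an aromatic carbon, ortho to a large group, turning phenyl into 2-methylphenyl, therefore leaves the number of compound 3 effectively unchanged, so this place accepts the added carbon without a readable gain or loss in antiproliferative activity. Nothing at hand bears on why the step is so small.

As far as these compounds go, whether a different group at the same place, such as an amine, a carboxylic acid or a longer chain, would move the number beyond the scatter remains open. Also open, from the compounds shown here alone, is whether the same methyl would give an equally small step on compound 2.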